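The source may hold more compounds than are shown below. What is called first, only, known or untested is meant among the compounds shown, and "the series" means these compounds.

Measured so far:

Compound 1, `CC(Cn1ncccc1=O)C(=N)S`, gives > 100 mg/kg in a functional assay on the whole organism (stomach) with Rattus norvegicus as the target; on this read-out lower numbers stand for an effect already at smaller amounts and higher numbers for an effect only at larger amounts of compound; this is a limit of the assay, not a number.

Compound 2, `Cc1cc(=O)n(CCC(=N)S)nc1-c1ccccc1`, gives > 100 mg/kg in this assay; this too is a limit.

Compound 3, `N=C(S)CCn1nc(-c2ccccc2)ccc1=O`, gives 87.3 mg/kg in this assay.

Among these three, only one measured step links two compounds that differ in a single place. The change is methyl in place of hydrogen on an aromatic carbon, and it brought an at least 1.1-fold higher number from compound 3 to compound 2 (0.05 log units; that floor lies within the scatter). Because 2 of the 3 values sit at the limit of > 100 mg/kg in this assay, at which 2 of the 3 values shown sit, the true size of this step cannot be told, only that it did not make the number smaller than the limit.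

Compound 1 and compound 3 share no single-point relation; the difference between the two cores is not broken down here.

The unmeasured compound 4, `Cc1ccc(=O)n(CC(C)C(=N)S)n1`, comes from compound 1 by methyl in place of hydrogen on an aromatic carbon. For the measured compounds named here, this is the same kind of change as the one from compound 3 to compound 2, but not the same: in compound 4 the methyl sits next to the ring nitrogen, meta to a group of 6 heavy atoms and para to a group of 1 heavy atom, whereas in compound 2 it sits ortho to a phenyl group, opposite the ring nitrogen, meta to a group of 1 heavy atom and para to a group of 5 heavy atoms.

Going by the values given here, for compound 4 the expected step is a step that the limit leaves unreadable from compound 1 to compound 4, resting on the fact that compound 1 already sits at > 100 mg/kg and that the one measured methyl step did not lower the number. Compound 4 is therefore estimated at 150 mg/kg, with an expected range from 90 mg/kg to 300 mg/kg, and most likely the assay will again report only a limit.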

Compound 4, dose for half-maximal effect: > 100 mg/kg
Compound 4: only a limit was reported; the forecaster's own chance of this, stated with the estimate: 80%; the middle value does not contradict the limit.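

Compound 1 and compound 4 both end at a limit of the assay rather than at a number, so no new step can be read between them, because both values sit at the same boundary: the limit of > 100 mg/kg in this assay, at which 3 of the 4 values shown sit.

The compounds shown leave open what the true numbers of compound 1, compound 2 and compound 4 are, and so how far, if at all, a methyl in place of hydrogen on an aromatic carbon moves the result in this assay for these compounds.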